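The source may hold more compounds than are shown below. What is called first, only, known or untested is meant among the compounds shown, and "the series" means these compounds.

Of the compounds shown here, three have been measured so far in a functional assay on DU-145 cells (Homo sapiens) for inhibition, read by trypan blue exclusion, with a stated time of 96 h; on this read-out lower numbers stand for stronger inhibition of growth and higher numbers for weaker inhibition of growth. Compound 1 `O=C(/C(=C\c1ccc(I)cc1)S(=O)(=O)c1ccc(Br)cc1)c1ccc(Br)cc1` gives 1000 nM in this assay. Compound 2 `Cc1ccc(CS(=O)(=O)/C(=C/c2c[nH]c3ccc(Br)cc23)C(=O)c2ccc(Cl)cc2)cc1` gives 10000 nM in this assay. Compound 3 `CC(=O)c1ccc(/C=C(/Sc2ccc(C)cc2)C(=O)c2ccc(Br)cc2)cc1` gives 50000 nM in this assay, the highest of the three numbers: compound 2 is the nearest to it, and compound 1 the furthest, both gaps beyond the usual scatter. None of these three pairs differs in only one place, so the numbers alone are what can be read from them.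

Compound 4 `Cc1ccc(S/C(=C/c2c[nH]c3ccccc23)C(=O)c2ccc(Br)cc2)cc1` is the compound that has not yet been measured. It differs from compound 3 as follows: 1H-indol-3-yl in place of 4-acetylphenyl on a double-bonded chain carbon bound to a double-bonded chain carbon. The same change of group, though joined with other changes, separates compound 2 from compound 3, and compound 2 shows the lower number of the two. On that basis the step from compound 3 to compound 4 is expected to be a modest one toward a lower number, a 2.0-fold lower number from compound 3 to compound 4 (0.30 log units; within the scatter), close to the edge of the scatter. Compound 4 is therefore estimated at 25000 nM in this assay, with a range from 8000 nM to 80000 nM.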

Compound 4, concentration for 50% growth inhibition: 10000 nM
Compound 4: middle estimate off by 2.5-fold (0.40 log units), on the high side; the measured number falls inside the stated range.
By their numbers in this assay, from the lowest: compound 1; then compounds 2 and 4 (each within the scatter of the next); then compound 3.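

In this assay, putting 1H-indol-3-yl in place of 4-acetylphenyl on a double-bonded chain carbon bound to a double-bonded chain carbon gives a 5.0-fold lower number from compound 3 to compound 4 (0.70 log units; beyond the scatter). Among the compounds shown here, this is the first view of this position with the rest of the compound held fixed: compound 2 and compound 3 also differ in other places, so their gap could not be assigned to this change alone. No measurement shown here accounts for the size or direction of the step.

As far as these compounds go, whether a phenyl group carrying an amine or a carboxylic acid in place of the acetyl would give a lower or higher number at this position remains open. From the compounds shown here alone, it is also open whether the same exchange would produce a step of similar size in a compound with a sulfonyl group in place of the sulfur link.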